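Flipping both ring stereocentres of compound 3

The source may report more compounds than this note shows. Statements on the series, on what has been measured and on what is new or still open speak of the compounds shown alone.

In a functional assay on Lu1 cells (Homo sapiens) for cytotoxicity, read by colorimetric assay and neutral red uptake, with a stated time of 72 h (a higher number here means a weaker inhibitor, a lower number a stronger inhibitor), compound 1 `CO[C@@H](C(=O)N[C@H]1CC[C@@H](O)CNC1=O)[C@H](O)[C@@H](O)[C@H](O)/C=C/C(C)(C)C` gives 23400 nM, compound 2 `CO[C@@H](C(=O)N[C@@H]1CCCCNC1=O)[C@H](O)[C@@H](O)[C@H](O)/C=C/C(C)(C)C` gives 500 nM, and compound 3 `CO[C@@H](C(=O)N[C@H]1CC[C@H](O)CNC1=O)[C@H](O)[C@@H](O)[C@H](O)/C=C/C(C)(C)C` gives 10000 nM. Compound 3 is therefore the second highest of the three numbers. The gaps around it are a 2.3-fold lower number from compound 1 to compound 3 (0.37 log units; beyond the scatter) and a 20-fold higher number from compound 2 to compound 3 (1.30 log units; beyond the scatter).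

Compound 4 `CO[C@@H](C(=O)N[C@@H]1CC[C@@H](O)CNC1=O)[C@H](O)[C@@H](O)[C@H](O)/C=C/C(C)(C)C` is the next structure, and its relation to the previous one is simple: the two compounds have the same atoms and bonds and differ only in configuration as drawn: 2 of 7 stereo elements differ; a stereocentre at a saturated ring carbon is drawn S in compound 3 and R in compound 4; a stereocentre at a saturated ring carbon is drawn S in compound 3 and R in compound 4. Only the three-dimensional arrangement changes.

For the measured compounds named here, two measured steps bear on this. The first is a 2.3-fold lower number from compound 1 to compound 3 (0.37 log units; beyond the scatter), and because of the fact that compounds 1 and 3 differ only in the configuration as drawn this modest step shows what one stereocentre alone did here. The second is a 47-fold lower number from compound 1 to compound 2 (1.67 log units; beyond the scatter), which is large. Compound 2 has a single ring stereocentre, drawn as the matching one in compound 4 and unlike that in compound 1 or compound 3. That large step also removes the hydroxyl group, however, so the data do not separate the two changes. A clearly lower number is thus expected, probably without reaching the value of compound 2, 500 nM. The estimated change is a 6.7-fold lower number from compound 3 to compound 4 (0.82 log units; beyond the scatter). Compound 4 is estimated at 1500 nM, with an expected range from 300 nM to 8000 nM.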

Compound 4, half-maximal inhibitory concentration: 17200 nM
Estimate against measurement, compound 4: 11-fold (1.06 log units) below, outside the stated range (above it).
By their numbers in this assay, from the lowest: compound 2; then compounds 3, 4 and 1 (each within the scatter of the next, the first and the last beyond it).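

In this assay, for the compounds shown here, inverting both ring stereocentres leaves a 1.7-fold higher number from compound 3 to compound 4 (0.24 log units; within the scatter), and inverting only one leaves a 1.4-fold lower number from compound 1 to compound 4 (0.13 log units; within the scatter); both steps lie within the scatter, while the one stereo step beyond it among the hydroxylated compounds is the modest 2.3-fold lower number from compound 1 to compound 3 (0.37 log units; beyond the scatter). With the remaining ring stereocentre drawn alike, hydroxy in place of hydrogen on a saturated ring carbon brings a 34-fold higher number from compound 2 to compound 4 (1.54 log units; beyond the scatter), a large step that involves no change of configuration. This pulls apart the two changes combined in a 47-fold lower number from compound 1 to compound 2 (1.67 log units; beyond the scatter), since most of that gap goes with the hydroxy group and little with the stereocentre, as the pair that contrasts only in configuration shows: the fact that compounds 1 and 4 differ only in the configuration as drawn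

The compounds shown leave open whether the hydroxy group itself matters or whether any other group on that ring carbon, such as a methoxy group, a fluorine atom or an amine, would raise the number as much. They also leave open how the ring without the hydroxy group behaves with its single stereocentre drawn the other way.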